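Swapping a Fluoro for a Cyano on the Shared Core

This account rests on a few compounds, and the source may have more. Where it says the series, first, only, none or still open, it means among the compounds named here.

Compound 1 `Fc1cc2nc(-c3cccnc3)n(C3CC3)c2cc1F`: 370 nM
Compound 2 `Fc1cncc(-c2nc3cc(F)c(Cl)cc3n2C2CC2)c1`: 251 nM
Compound 3 `Cc1ccncc1-c1nc2cc(F)c(F)cc2n1C1CC1`: 723 nM

Of the compounds shown here, three have been measured in an assay on V79 cells for inhibition of cytochrome P450 11B1, mitochondrial (Homo sapiens), read by HTRF, with a stated time of 1 h; a lower number here means a stronger inhibitor, a higher number a weaker inhibitor. Compound 1 gives 370 nM and stands second highest of the three numbers. Its nearest neighbour is compound 2 with 251 nM, a gap that lies within the usual scatter of the assay. For the measured compounds named here, its furthest neighbour is compound 3 with 723 nM, and the one step between compounds that differ in a single place, a 2.0-fold higher number from compound 1 to compound 3 (0.29 log units; within the scatter), is also within the scatter.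

Compound 4 `N#Cc1cc2c(cc1F)nc(-c1cccnc1)n2C1CC1` is not yet measured. It differs from compound 1 by cyano in place of fluoro on an aromatic carbon. Going by the values given here, no measured step concerns this place on the shared core: the only measured step, a 2.0-fold higher number from compound 1 to compound 3 (0.29 log units; within the scatter), touches a different ring, and compound 2 differs from compound 1 on that other ring too. Nothing measured therefore argues for a step in either direction beyond the scatter, and the uncertainty is correspondingly wide.

On this basis compound 4 is expected to give about 400 nM in this assay, most likely between 120 nM and 1300 nM. The step this estimate means is a 1.1-fold higher number from compound 1 to compound 4 (0.03 log units; within the scatter).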

Compound 4, half-maximal inhibitory concentration: 117 nM
Beside the measured number, compound 4's estimate is 3.4-fold (0.53 log units) above it, outside the stated range (below it).
By their numbers in this assay, from the lowest: compound 4; then compounds 2, 1 and 3 (each within the scatter of the next, the first and the last beyond it).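

The earlier compounds gave no reading at this place on the shared core, and cyano in place of fluoro now supplies the first: in this assay the change gives a 3.2-fold lower number from compound 1 to compound 4 (0.50 log units; beyond the scatter) and is the only step among the compounds shown that lies beyond the scatter. So this aromatic carbon, ortho to a fluoro group, is a place where changing the group can move the number by more than repeat measurements would. Cyano brings two heavy atoms, a triple bond and a hydrogen-bond acceptor where fluoro brings one heavy atom and no acceptor, but no measurement shown links any of these differences to the change in the number.

As far as these compounds go, whether the step belongs to cyano alone or would also appear with other groups at this place, such as an amine, a methoxy group or a carboxylic acid, stays open. Also open, from the compounds shown here alone, is whether the same swap would give a similar step on compound 3, which carries a methyl group on its other ring.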